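A few compounds are considered here, and "the series" means these few. Any claim that something is new, unique, unknown or untested is made for them only; others in the source may bear on it.

Measured in a functional assay for inhibition, with Rattus norvegicus as the target; a higher number here means a weaker inhibitor, a lower number a stronger inhibitor:
- compound 1 `CC(/N=c1\c(O)c(O)\c1=N/c1cccnc1O)C(C)(C)C`: > 30000 nM
- compound 2 `CC(/N=c1\c(O)c(O)\c1=N/c1ccccc1)C(C)(C)C`: 5400 nM

Compound 1 stands at a limit, not a number: the limit of > 30000 nM in this assay, at which 1 of the 2 values shown sits. Among the compounds with values here, compound 2 at 5400 nM therefore holds the only numeric value so far.

Compound 3 `CC(/N=c1\c(O)c(O)\c1=N/c1ccc(Br)cc1)C(C)(C)C` has bromo in place of hydrogen on an aromatic carbon, para to a large group, taking phenyl to 4-bromophenyl: bromo in place of hydrogen on an aromatic carbon.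

Within the data shown here, the one measured step is an at least 5.5-fold lower number from compound 1 to compound 2 (0.74 log units; beyond the scatter). It exchanges the whole group on a double-bonded nitrogen, so it shows that this assay responds to changes in that group, but it gives no direct measure of a bromo effect. A modest move to a lower number is expected, held loosely, and a result within the scatter would not surprise. The estimate is a 3.0-fold lower number from compound 2 to compound 3 (0.48 log units; beyond the scatter). For compound 3 the expected value is 1800 nM, with an estimated range of 300 nM to 9000 nM.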

Compound 3, half-maximal inhibitory concentration: 1260 nM
Beside the measured number, compound 3's estimate is 1.4-fold (0.15 log units) above it; low and high end bracket the measured number.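

In this assay, within the data shown here, the earlier compounds showed only that exchanging the whole group on the double-bonded nitrogen moves the number. Bromo in place of hydrogen on an aromatic carbon, para to a large group, now isolates a single-atom change on the phenyl ring and gives it a size of its own: a 4.3-fold lower number from compound 2 to compound 3 (0.63 log units; beyond the scatter). The wider exchange, 4-bromophenyl in place of 2-hydroxypyridin-3-yl, gives an at least 23-fold lower number from compound 1 to compound 3 (1.37 log units; beyond the scatter), but this is a bound and not a full size, since compound 1 is held at a limit rather than a number: the limit of > 30000 nM in this assay, at which 1 of the 3 values shown sits.

As far as these compounds go, whether this step is specific to bromo, or would also appear with chloro, methoxy or an amine on the same carbon, remains open. From the compounds shown here alone, the effect of bromo on any other carbon of the ring also remains open.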